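Series notes: alpha-1D binding around compound 1

The source may report more compounds than this note shows. Statements on the series, on what has been measured and on what is new or still open speak of the compounds shown alone.

Among the compounds with values here, compound 1 `COc1ccc(S(C)(=O)=O)c(NCC2=NCCN2)c1` is the weakest binder among the three compounds measured so far. In an assay for binding affinity to Alpha-1D adrenergic receptor (Homo sapiens), read by radioligand binding (on this read-out higher numbers stand for weaker inhibition and lower numbers for stronger inhibition), compound 1 gives 7590 nM, the highest of the three numbers. Compound 3 `CCS(=O)(=O)c1ccccc1NCC1=NCCN1` stands nearest, giving 2240 nM in this assay, and compound 2 `COc1ccc(SC)c(NCC2=NCCN2)c1` stands furthest, giving 107 nM. Within the data shown here, the one single-point step measured within the set, a 71-fold lower number from compound 1 to compound 2 (1.85 log units; beyond the scatter), concerns the sulfur-bearing group and not the position now in question.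

Compound 4 `CS(=O)(=O)c1ccc(C(F)(F)F)cc1NCC1=NCCN1` differs from compound 1 in one place: trifluoromethyl in place of methoxy on an aromatic carbon. Among the measured compounds shown here, no measured step in the set alters this position on its own; compound 3 carries no group there but also a different sulfonyl substituent, so its value relative to compound 1 cannot be split into separate parts. The expectation for compound 4 therefore rests on little more than the spread of the set, and is for a step of a 2.2-fold lower number from compound 1 to compound 4 (0.34 log units; beyond the scatter) in this assay, most likely near the edge of the scatter, with a somewhat lower number slightly favoured. Compound 4 is accordingly expected to give about 3500 nM in this assay, with a plausible range between 800 nM and 15000 nM.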

Compound 4, inhibition constant: < 15900 nM
Compound 4: a limit, no number (the forecaster's own chance of this, stated with the estimate: 10%); the middle value is on the limit's open side.
By their numbers in this assay, from the lowest: compound 2; then compound 3; then compound 1.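

Compound 4 gives a limit of the assay and not a number in this assay, so the step between compound 1 and compound 4 cannot be read: the limit of < 15900 nM in this assay, at which 1 of the 4 values shown sits.

The compounds shown leave open whether trifluoromethyl in place of methoxy on an aromatic carbon changes the number in this assay at all, and in which direction.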